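This account rests on a few compounds, and the source may have more. Where it says the series, first, only, none or still open, it means among the compounds named here.

Compound 1 `Cn1nccc1-c1cnc(NCc2c(F)ccc3c2CCO3)c2cn[nH]c(=O)c12`: 2000 nM
Compound 2 `C[C@@H]1CC(=O)N(c2cnc(NCc3c(F)ccc4c3CCO4)n3cnnc23)C1`: 130000 nM
Compound 3 `CN(C)Cc1ccc2c(c1)CN(c1cnc(NCc3c(F)ccc4c3CCO4)n3cnnc13)C2=O`: 12000 nM

In a physicochemical assay for solubility, read by LC-MS, in phosphate buffer, with a stated time of 24 h, at pH 7.4 (on this read-out higher numbers stand for higher solubility and lower numbers for lower solubility), compound 2 stands highest of the three numbers, with compound 3 next and compound 1 lowest, both gaps lying beyond the scatter. Compound 4 `C[C@H]1CC(=O)N(c2cnc(NCc3c(F)ccc4c3CCO4)n3cnnc23)C1` is the partner of compound 2: the two compounds have the same atoms and bonds and differ only in configuration as drawn: 1 of 1 stereo elements differ; a stereocentre at a saturated ring carbon is drawn R in compound 2 and S in compound 4. For the measured compounds named here, no step of this kind between two measured compounds is available here. With every atom and bond kept and only the drawn configuration changed, the expectation is for no step beyond the scatter in this assay. Compound 4 is therefore estimated at 130000 nM, within a range of 65000 nM to 260000 nM. That estimate means a step of no change at the digits printed from compound 2 to compound 4 (within the scatter), expected to be no more than the ordinary scatter of repeated measurements.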

Compound 4, solubility: 200000 nM
Estimate against measurement, compound 4: 1.5-fold (0.19 log units) below, and the stated range covers the measured number.
By their numbers in this assay, from the lowest: compound 1; then compound 3; then compounds 2 and 4 (each within the scatter of the next).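

In this assay, the pair gives a 1.5-fold higher number from compound 2 to compound 4 (0.19 log units; within the scatter). Unlike the earlier compounds, which differ in more than one place, this pair isolates a single change: the fact that compounds 2 and 4 differ only in the configuration as drawn. At this saturated ring carbon, then, drawing the stereocentre R or S gives no difference that can be told apart from the scatter of repeated measurements.

From the compounds shown here alone, whether a carboxylic acid or a hydroxyl group at this ring carbon would shift the number remains open. So does whether the two configurations would still match with such a group in place.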